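The source may hold more compounds than are shown below. What is called first, only, known or untested is meant among the compounds shown, and "the series" means these compounds.

Compound 2 `Clc1ccc(-c2cn3ccnc3c(-c3ccc4ncn(C5CCCCC5)c4c3)n2)cc1` and compound 1 `COc1ccc(-c2cn3ccnc3c(-c3ccc4ncn(C5CCCCC5)c4c3)n2)cc1` share one core and differ only in a single group on an aromatic carbon. In a functional assay on OVCAR-8 cells (Homo sapiens) for inhibition, read by sulforhodamine B assay, with a stated time of 48 h, tested at 10 uM (a higher number here means more inhibition at the concentration tested (going by the name of the read-out), a lower number less inhibition), compound 1 gives 71.2%, while compound 2 gives 3.78%, the lower of the two numbers measured. Going by the values given here, the single step measured, a number 67.4 percentage points lower from compound 1 to compound 2 (beyond the scatter), is large. Compound 3 `FC(F)(F)c1cccc(-c2cn3ccnc3c(-c3ccc4ncn(C5CCCCC5)c4c3)n2)c1` follows from compound 2 by the change (3-(trifluoromethyl)phenyl in place of 4-chlorophenyl on an aromatic carbon). Among the compounds with values here, no measured step bears directly on this change: the only step measured, that from compound 1 to compound 2, swapped one group for another at the same place and showed how strongly this position can shift the read-out, but nothing shows what the entering group does there. For compound 3 the expected outcome in this assay is therefore uncertain, and the step of a number 11.2 percentage points higher from compound 2 to compound 3 (beyond the scatter) is expected to be modest at most. Compound 3 is estimated at 15%, within a range from 0% to 50%.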

Compound 3, a percentage reported as inhibition, at one concentration (the size of the read-out at that concentration, not a potency): 10.1%
The estimate for compound 3 lay 4.9 percentage points above the measured number; the measured number falls inside the stated range.
By their numbers in this assay, from the lowest: compounds 2 and 3 (each within the scatter of the next); then compound 1.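

In this assay, the step from 4-chlorophenyl to 3-(trifluoromethyl)phenyl, a number 6.3 percentage points higher from compound 2 to compound 3 (within the scatter) in size, does not separate the two groups, although the entering group differs in both its substituent and where that substituent sits on the phenyl ring. The step of a number 61.1 percentage points lower from compound 1 to compound 3 (beyond the scatter) shows that the large fall first seen with the chloro group also occurs with a second replacement of 4-methoxyphenyl, so among these three compounds only compound 1 gives a high number. No evidence is available here to explain this difference.

On these data alone, whether the high number needs the methoxy group itself remains open. A hydroxyl, an amine or a longer ether such as ethoxy at the same place on the phenyl ring could test this.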